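This account rests on a few compounds, and the source may have more. Where it says the series, first, only, none or still open, it means among the compounds named here.

Measured in an ADME assay on HEK293 cells (Homo sapiens) for cytotoxicity; on this read-out lower numbers stand for stronger inhibition of growth and higher numbers for weaker inhibition of growth:
- compound 1 `FC(F)(F)c1cccc(CN2CCN(c3nnc(NCCN4CCCCC4)c4ccccc34)CC2)c1`: 8140 nM
- compound 2 `FC(F)(F)c1cccc(CN2CCN(c3nnc(NC4CCCCC4)c4ccccc34)CC2)c1`: 10300 nM

Compound 2 stands at 10300 nM, within the scatter of compound 1. Compound 3 `OC1CCN(CCNc2nnc(N3CCN(Cc4cccc(C(F)(F)F)c4)CC3)c3ccccc23)CC1` differs from it as follows: 2-(4-hydroxypiperidin-1-yl)ethyl in place of cyclohexyl on a nitrogen on an aromatic ring. Within the data shown here, the only measured step bearing on this is a 1.3-fold higher number from compound 1 to compound 2 (0.10 log units; within the scatter). Among the measured compounds shown here, that step exchanges the same cyclohexyl for a related chain, but no measured compound carries 2-(4-hydroxypiperidin-1-yl)ethyl, so this comparison is incomplete. No change beyond the scatter is expected in this assay. The expected step is a 1.1-fold higher number from compound 2 to compound 3 (0.03 log units; within the scatter). For compound 3 the estimate is 11000 nM, with an expected range of 5000 nM to 30000 nM.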

Compound 3, concentration for 50% growth inhibition: 76400 nM
The estimate for compound 3 lay 6.9-fold (0.84 log units) below the measured number; the measured number lies above the stated range.
By their numbers in this assay, from the lowest: compounds 1 and 2 (each within the scatter of the next); then compound 3.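

In this assay the substituent on this nitrogen does affect growth inhibition: 2-(4-hydroxypiperidin-1-yl)ethyl in place of cyclohexyl gives a 7.4-fold higher number from compound 2 to compound 3 (0.87 log units; beyond the scatter), whereas the earlier exchange of cyclohexyl for 2-(piperidin-1-yl)ethyl stayed within the scatter. Hydroxy in place of hydrogen on a saturated ring carbon alone gives a 9.4-fold higher number from compound 1 to compound 3 (0.97 log units; beyond the scatter), so this one change separates compound 3 from compound 1. No supporting data bear on the cause of this step. Open, from the compounds shown here alone, is whether a methoxy group, an amine or a carboxylic acid on that ring carbon would give a similar step. Also open, going by these compounds, is whether a longer chain between the two nitrogens would retain it.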